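The compounds below may be only part of what the source reports. "The series", "measured", "known", "first", "only" and "open" are said of these compounds alone.

Compound 1 `O=C(NCCO)c1cc(-c2ccc(Cl)cc2Cl)n[nH]1`: 44 nM
Compound 2 `O=C(NCCO)c1cc(-c2cc(F)c(Cl)cc2Cl)n[nH]1`: 100 nM
Compound 3 `O=C(NCCCCO)c1cc(-c2ccc(Cl)cc2Cl)n[nH]1`: 35 nM

Of the compounds shown here, three sharing one core have been tested in an assay on isolated protein for inhibition of alkaline phosphatase, tissue-nonspecific isozyme (Homo sapiens); a lower number here means a stronger inhibitor, a higher number a weaker inhibitor. Compound 2 gives the highest number of the three: compound 1 gives 44 nM and the step of a 2.3-fold higher number from compound 1 to compound 2 (0.36 log units; beyond the scatter) lies beyond the scatter, while compound 3 gives 35 nM, also a lower number than compound 2. Compound 4 `O=C(c1cc(-c2cc(F)c(Cl)cc2Cl)n[nH]1)N(CCO)CCO` has not yet been measured. Against compound 2 the change is 2-hydroxyethyl in place of hydrogen on an amide-type nitrogen; cut one bond further out, the (2-hydroxyethyl)amino becomes bis(2-hydroxyethyl)amino, so the hydrogen on the amide nitrogen is gone. Among the compounds with values here, no measured pair shows exactly this change. The closest is a 1.3-fold lower number from compound 1 to compound 3 (0.10 log units; within the scatter), where a 2-hydroxyethyl was added on the chain carbon instead, and the number stayed within the scatter. Within the data shown here, that suggests this part of the molecule accepts an extra 2-hydroxyethyl, but the loss of the amide hydrogen is covered by no measured step. The expected step is therefore a 1.3-fold higher number from compound 2 to compound 4 (0.11 log units; within the scatter), small and not clearly beyond the scatter, with a wide range. Compound 4 is estimated at 130 nM, expected between 50 nM and 350 nM.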

Compound 4, half-maximal inhibitory concentration: 127 nM
Compound 4: the middle estimate sits 1.0-fold (0.01 log units) above what was measured; the measured number falls inside the stated range.
By their numbers in this assay, from the lowest: compounds 3 and 1 (each within the scatter of the next); then compounds 2 and 4 (each within the scatter of the next).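

In this assay, a second 2-hydroxyethyl in place of the amide hydrogen gives a 1.3-fold higher number from compound 2 to compound 4 (0.10 log units; within the scatter), so compound 4 cannot be told apart from compound 2. The earlier compounds shown here changed only the chain or the aromatic ring and always kept that hydrogen, whereas this pair shows that, with the fluoro-bearing ring of compound 2, the amide-type nitrogen can carry a second chain and lose its hydrogen without a step beyond the scatter. Nothing available explains why the number holds.

The compounds shown leave open whether a different group on this nitrogen, such as a methyl, a longer chain ending in hydroxy or a chain ending in an amine or a carboxylic acid, would fare the same. They also leave open whether this replacement would give a similar step on compound 1, which has no fluoro.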